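Shortening the butyl chain of compound 2

This account rests on a few compounds, and the source may have more. Where it says the series, first, only, none or still open, it means among the compounds named here.

In an ADME assay on the whole organism (plasma) for pharmacokinetics, with Rhesus monkey (Macaca mulatta) as the target, with a stated time of 24 h, at a dose of 3 mg/kg by the oral route (on this read-out lower numbers stand for lower exposure and higher numbers for higher exposure at the dose given), compound 1 (`CCCC[C@H](NC(=O)[C@@H]1[C@H]2[C@@H](CN1C(=O)[C@@H](NC(=O)NC1([C@H]3CCCS3(=O)=O)CCCCC1)C(C)(C)C)C2(C)C)C(=O)C(=O)NC1CC1`) gives 277 ng.h/mL, while compound 2 (`CCCC[C@H](NC(=O)[C@@H]1[C@H]2[C@@H](CN1C(=O)[C@@H](NC(=O)NC1([C@H]3CCCS3(=O)=O)CCCCC1)C1(C)CCCCC1)C2(C)C)C(=O)C(=O)NC1CC1`) gives 6590 ng.h/mL, the higher of the two numbers. That is a 24-fold higher number from compound 1 to compound 2 (1.38 log units; beyond the scatter), a large step that came with 1-methylcyclohexyl in place of tert-butyl. Compound 3 (`CCC[C@H](NC(=O)[C@@H]1[C@H]2[C@@H](CN1C(=O)[C@@H](NC(=O)NC1([C@H]3CCCS3(=O)=O)CCCCC1)C1(C)CCCCC1)C2(C)C)C(=O)C(=O)NC1CC1`) changes a different place: hydrogen in place of methyl on a saturated chain carbon, four bonds along the chain from an amide-type nitrogen and a carbonyl carbon, which turns butyl to propyl. Among the measured compounds shown here, the one measured step involves another group, so it does not size this change, and no shift beyond the scatter is expected in this assay. The expected change is a 1.3-fold lower number from compound 2 to compound 3 (0.12 log units; within the scatter). Compound 3 is estimated at 5000 ng.h/mL, within a range of 1500 ng.h/mL to 15000 ng.h/mL.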

Compound 3, area under the concentration-time curve: 14900 ng.h/mL
Compound 3: the middle estimate sits 3.0-fold (0.47 log units) below what was measured; the measured number falls inside the stated range.
By their numbers in this assay, from the lowest: compound 1; then compound 2; then compound 3.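

In this assay, shortening butyl to propyl gives a 2.3-fold higher number from compound 2 to compound 3 (0.35 log units; beyond the scatter), so this chain is not a neutral place: losing a single carbon moves exposure beyond the usual scatter. Compound 1 and compound 2 differ elsewhere and said nothing about the length of this chain. Nothing available here explains the rise. From the compounds shown here alone, whether exposure would rise further with an ethyl chain remains open. So does the effect of a pentyl chain or of a chain carrying an amine.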